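Repositioning a Methoxy Group on the Carbonyl-Bound Ring

The source may hold more compounds than are shown below. What is called first, only, known or untested is meant among the compounds shown, and "the series" means these compounds.

Of the compounds shown here, three sharing a core have been measured in a functional assay on MCF7 cells (Homo sapiens) for antiproliferative activity, read by XTT assay, with a stated time of 72 h; a higher number here means a weaker inhibitor, a lower number a stronger inhibitor. Compound 1 `COc1ccc(-c2cc3ccccc3nc2/C=C/C(=O)c2ccc(F)cc2)cc1` gives 5450 nM, compound 2 `COc1ccc(-c2cc3ccccc3nc2/C=C/C(=O)c2ccc(O)cc2)cc1` gives 6710 nM, and compound 3 `COc1ccc(-c2cc3ccccc3nc2/C=C/C(=O)c2ccc(OC)cc2OC)cc1` gives 6260 nM. Compound 3 stands second highest of the three numbers; its nearest neighbour is compound 2 and its furthest is compound 1, yet every gap lies within the scatter. The steps recorded so far are a 1.2-fold higher number from compound 1 to compound 2 (0.09 log units; within the scatter), a 1.1-fold higher number from compound 1 to compound 3 (0.06 log units; within the scatter) and a 1.1-fold lower number from compound 2 to compound 3 (0.03 log units; within the scatter), none of them beyond the scatter. Compound 4 `COc1ccc(-c2cc3ccccc3nc2/C=C/C(=O)c2c(OC)cccc2OC)cc1` has not yet been measured; it differs from compound 3 by 2,6-dimethoxyphenyl in place of 2,4-dimethoxyphenyl on a carbonyl carbon. The steps bearing on this change are those that alter the group on the carbonyl carbon, a 1.1-fold higher number from compound 1 to compound 3 (0.06 log units; within the scatter) and a 1.1-fold lower number from compound 2 to compound 3 (0.03 log units; within the scatter), both small. No step beyond the scatter is therefore expected in this assay, a 1.0-fold higher number from compound 3 to compound 4 (0.00 log units; within the scatter). The estimate for compound 4 in this assay is 6300 nM, with a range from 3000 nM to 13000 nM.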

Compound 4, half-maximal inhibitory concentration: 4520 nM
Estimate against measurement, compound 4: 1.4-fold (0.14 log units) above; measured number inside the range.
By their numbers in this assay, from the lowest: compounds 4, 1, 3 and 2 (each within the scatter of the next).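

In this assay, moving one methoxy group so that 2,6-dimethoxyphenyl replaces 2,4-dimethoxyphenyl on the carbonyl carbon gives a 1.4-fold lower number from compound 3 to compound 4 (0.14 log units; within the scatter), so rearranging the same atoms at this place stays within the scatter, as the earlier changes of this group did. The comparisons with the other two groups on that carbon, a 1.5-fold lower number from compound 2 to compound 4 (0.17 log units; within the scatter) and a 1.2-fold lower number from compound 1 to compound 4 (0.08 log units; within the scatter), also lie within the scatter, so the four groups shown at this place cannot be told apart in this assay. Nothing shown here offers an explanation for this flat result.

The compounds leave open whether any other group on the carbonyl carbon, such as a phenyl ring carrying an amine or a carboxylic acid, would give a step beyond the scatter. They also leave open whether changes elsewhere on the shared core would do so.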